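Bis-benzylidene cyclohexanone series: cytotoxicity notes, compound 4

A few compounds are considered here, and "the series" means these few. Any claim that something is new, unique, unknown or untested is made for them only; others in the source may bear on it.

Measured so far in a functional assay on SW-620 cells (Homo sapiens) for cytotoxicity, read by MTT assay, with a stated time of 72 h; on this read-out higher numbers stand for weaker inhibition and lower numbers for stronger inhibition:
- compound 1, `COc1cccc(/C=C2\CCC/C(=C\c3ccccc3Cl)C2=O)c1OC`, gives 10300 nM
- compound 2, `COc1cccc(/C=C2\CCC/C(=C\c3cccc(Br)c3)C2=O)c1OC`, gives 8800 nM
- compound 3, `COc1ccc(/C=C2\CCC/C(=C\c3cccc(OC)c3OC)C2=O)cc1OC`, gives 6400 nM

Compound 2 stands second highest of the three numbers. Its nearest neighbour is compound 1, whose number is higher by a margin within the scatter; its furthest is compound 3, whose number is lower, also within the scatter. Among the compounds with values here, the only single-point step measured so far is the one from compound 1 to compound 2, a 1.2-fold lower number from compound 1 to compound 2 (0.07 log units; within the scatter), a swap of one halogenated phenyl for another that did not move the number beyond the scatter.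

Compound 4, `COc1cccc(/C=C2\CCC/C(=C\c3ccc(O)c(Cl)c3)C2=O)c1OC`, differs from compound 2 as follows: 3-chloro-4-hydroxyphenyl in place of 3-bromophenyl on a double-bonded chain carbon bound to a double-bonded ring carbon. The step that bears on it is the swap of aryl groups at the same place, which was flat. Within the data shown here, no measured step covers the hydroxyl that enters here, so there is nothing to support a move in either direction, and the expectation is a step of about a 1.1-fold lower number from compound 2 to compound 4 (0.04 log units; within the scatter) in this assay, none beyond the scatter. Compound 4 is therefore estimated at 8000 nM, with a range from 3000 nM to 20000 nM.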

Compound 4, half-maximal inhibitory concentration: 16800 nM
For compound 4 the middle estimate is 2.1-fold (0.32 log units) below the measured one, and the stated range covers the measured number.
By their numbers in this assay, from the lowest: compounds 3, 2, 1 and 4 (each within the scatter of the next, the first and the last beyond it).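

In this assay the place on a double-bonded chain carbon bound to a double-bonded ring carbon now carries a group with a hydrogen-bond donor, and the exchange of 3-bromophenyl for 3-chloro-4-hydroxyphenyl gives a 1.9-fold higher number from compound 2 to compound 4 (0.28 log units; within the scatter) in the series. Measured against 2-chlorophenyl at the same place, the same group gives a 1.6-fold higher number from compound 1 to compound 4 (0.21 log units; within the scatter) so neither step leaves the scatter, and the flat picture first seen with the two halogenated phenyl groups extends to an aryl group bearing a hydroxyl. No measurement on hand speaks to what lies behind these numbers.

The change from compound 2 to compound 4 exchanges the bromine for a chlorine and brings in the hydroxyl in one step, so the compounds shown do not separate what each of these contributes. Going by these compounds, whether an amine or a carboxylic acid on the phenyl ring at this place would give a step beyond the scatter also stays open.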